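Swapping trifluoromethyl for chloro on compound 2

This account rests on a few compounds, and the source may have more. Where it says the series, first, only, none or still open, it means among the compounds named here.

In a physicochemical assay for solubility (a higher number here means a more soluble compound, a lower number a less soluble compound), compound 2 (`O=C(O)c1ccc(C(=O)/C(=C\c2ccc(F)c([N+](=O)[O-])c2)SCc2ccc(C(F)(F)F)cc2)cc1`) gives < 1000 ug/mL, which is a limit of the assay and not a number. Compound 1 (`O=C(O)c1ccc(C(=O)/C(=C\c2ccc(F)c([N+](=O)[O-])c2)Sc2ccc(Br)cc2)cc1`) gives < 1000 ug/mL, which is also a limit. Compound 3 (`O=C(O)c1ccc(C(=O)/C(=C\c2ccc(Br)c([N+](=O)[O-])c2)SCc2ccc(Cl)cc2Cl)cc1`) gives < 1000 ug/mL, again a limit. Compound 2 therefore has no exact position in the series, and the whole picture is the limit of < 1000 ug/mL in this assay, at which 3 of the 3 values shown sit.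

Compound 4 (`O=C(O)c1ccc(C(=O)/C(=C\c2ccc(F)c([N+](=O)[O-])c2)SCc2ccc(Cl)cc2)cc1`) differs from compound 2 at one place: chloro in place of trifluoromethyl on an aromatic carbon. Seen as a whole group, 4-(trifluoromethyl)benzyl becomes 4-chlorobenzyl. For the measured compounds named here, the only measured step is a step that the two limits leave unreadable from compound 1 to compound 2, and it offers no size to carry over. Going by the values given here, no measured step shows this exchange either, so no direction can be argued and no change beyond the scatter is expected. The expected change is a step that the limit leaves unreadable from compound 2 to compound 4. The assay will most likely report only a limit again. If a number does appear, compound 4 is estimated at 300 ug/mL, with an expected range of 60 ug/mL to 1000 ug/mL.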

Compound 4, solubility: < 1000 ug/mL
Compound 4 ended at the assay's limit; the forecaster's own chance of this, stated with the estimate: 90%; the middle value is on the limit's open side.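

No step can be read between compound 1, compound 2 and compound 4 in this assay, and every compound shown stays at one limit: the limit of < 1000 ug/mL in this assay, at which 4 of the 4 values shown sit.

The compounds shown leave open how their true solubilities compare, and whether chloro in place of trifluoromethyl changes solubility at all.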